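Swapping a methoxyphenyl for an ethoxypyrimidinyl

This account rests on a few compounds, and the source may have more. Where it says the series, first, only, none or still open, it means among the compounds named here.

Compound 1, `C[C@@H]1CN(c2sc(CO)nc2-c2nc3ccccc3[nH]2)CCN1C(=O)Cn1cnc2cccnc21`, gives only a limit in a functional assay on U2OS cells for antagonist activity at C-X-C chemokine receptor type 3 (Homo sapiens), read by beta-arrestin recruitment (on this read-out higher numbers stand for weaker inhibition and lower numbers for stronger inhibition), namely > 10000 nM. Compound 2, `C[C@@H]1CN(c2sc(C3COC3)nc2-c2nc3ccccc3[nH]2)CCN1C(=O)Cn1cnc2cccnc21`, gives 6220 nM in this assay. Compound 3, `COc1ccc(-c2nc(C(F)(F)F)sc2N2CCN(C(=O)Cn3cnc4cccnc43)[C@H](C)C2)cc1`, gives 131 nM in this assay.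

Compound 3 therefore stands lowest of the two numbers in this assay, with compound 2 well above it and compound 1 known only as a limit (the limit of > 10000 nM in this assay, at which 1 of the 3 values shown sits). Within the data shown here, the only measured step, an at least 1.6-fold lower number from compound 1 to compound 2 (0.20 log units; that floor lies within the scatter), concerns a different substituent on the shared core and its size lies within the scatter, so it does not bear on the change that leads to compound 4.

Compound 4, `CCOc1ncc(-c2nc(C(F)(F)F)sc2N2CCN(C(=O)Cn3cnc4cccnc43)[C@H](C)C2)cn1`, differs from compound 3 in one place: 2-ethoxypyrimidin-5-yl in place of 4-methoxyphenyl on an aromatic carbon. Among the measured compounds shown here, no measured pair shows the effect of exchanging this aryl group, so nothing in the numbers points to a direction for this assay. The expectation is therefore a step no larger than the scatter, written as a 1.5-fold higher number from compound 3 to compound 4 (0.18 log units; within the scatter), with the uncertainty widened by the absence of any matching precedent. Compound 4 is estimated at 200 nM in this assay, between 60 nM and 700 nM.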

Compound 4, half-maximal inhibitory concentration: 20 nM
Beside the measured number, compound 4's estimate is 10-fold (1.00 log units) above it, outside the stated range (below it).
By their numbers in this assay, from the lowest: compound 4; then compound 3; then compound 2. At a limit, above all of these: compound 1.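

At the aromatic carbon next to the ring nitrogen of the five-membered aromatic ring with 1 nitrogen and 1 sulfur, the aryl group proves to count for a good deal: in this assay, 2-ethoxypyrimidin-5-yl in place of 4-methoxyphenyl gives a 6.6-fold lower number from compound 3 to compound 4 (0.82 log units; beyond the scatter). The only earlier step, an at least 1.6-fold lower number from compound 1 to compound 2 (0.20 log units; that floor lies within the scatter), concerned a different place and a different substituent, so this is the first change shown that moves the number beyond the scatter, and it does so with a six-membered aromatic ring with 2 hetero atoms and 3 hydrogen-bond acceptors entering where a carbon-only ring with 1 hydrogen-bond acceptor leaves. Nothing measured here accounts for why this exchange lowers the number.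

Ring and alkoxy chain change together in this step, so the compounds shown leave open how much of it belongs to the ring nitrogens and how much to ethoxy over methoxy. Also open, from the compounds shown here alone, is how an amine, a carboxylic acid or a longer alkoxy chain such as propoxy would fare on the same ring in this assay.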